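The source may report more compounds than this note shows. Statements on the series, on what has been measured and on what is new or still open speak of the compounds shown alone.

Measured so far: compound 1 `Cc1cc(OC(=O)C(C)(C)CCCCO[N+](=O)[O-])n(-c2ccccc2)n1` with 0.222 h; compound 2 `Cc1cc(OC(=O)c2ccc(OCCCO[N+](=O)[O-])cc2)n(-c2ccccc2)n1` with 0.0833 h; compound 3 `Cc1cc(OC(=O)c2ccc(CC(CO[N+](=O)[O-])O[N+](=O)[O-])cc2)n(-c2ccccc2)n1` with 0.118 h.

In an ADME assay on a cell-free system (serum, Homo sapiens) for metabolic stability, read by HPLC, tested at 250 uM (a higher number here means that the compound lasts longer, a lower number that the compound disappears faster), compound 3 gives 0.118 h. Its number sits among those of compound 2 and compound 1, and the gap to each of them lies within the usual scatter, so none of the three can be told apart with confidence. Compound 4 `Cc1cc(OC(=O)c2ccc(CCCO[N+](=O)[O-])cc2)n(-c2ccccc2)n1` has not yet been measured. It differs from compound 3 in one place: hydrogen in place of nitrooxy on a saturated chain carbon bound to two saturated chain carbons. Within the data shown here, no measured pair shows this change, so its effect is unknown. Given that all three measured numbers sit close together, no step beyond the scatter is expected in this assay. For compound 4 a value near 0.12 h is expected, within 0.06 h to 0.25 h, meaning a step of a 1.0-fold higher number from compound 3 to compound 4 (0.01 log units; within the scatter).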

Compound 4, half-life in the serum assay: 0.0667 h
Compound 4: the middle estimate sits 1.8-fold (0.26 log units) above what was measured; the measured number falls inside the stated range.
By their numbers in the serum assay, from the lowest: compounds 4, 2, 3 and 1 (each within the scatter of the next, the first and the last beyond it).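

In the serum assay, hydrogen in place of nitrooxy on a saturated chain carbon bound to two saturated chain carbons gives a 1.8-fold lower number from compound 3 to compound 4 (0.25 log units; within the scatter), and 3-(nitrooxy)propyl in place of 3-(nitrooxy)propoxy on an aromatic carbon gives a 1.2-fold lower number from compound 2 to compound 4 (0.10 log units; within the scatter), so neither change can be told apart from repeat variation. In a physicochemical assay for metabolic stability, read by HPLC (on this read-out lower numbers stand for a shorter-lived compound and higher numbers for a longer-lived compound), compound 3 gives 8 h and compound 4 gives 13 h, two values also within the scatter of each other. Nothing available explains these half-lives.

Still open, as far as these compounds go, is whether an amine or a carboxylic acid on that saturated chain carbon would give a step beyond the scatter in either assay.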